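The source may report more compounds than this note shows. Statements on the series, on what has been measured and on what is new or still open speak of the compounds shown alone.

Compound 1 `Cc1ccc(Nc2cc(NC(=O)Nc3c(Cl)cccc3Cl)ncn2)cc1C` is one of two compounds with a value in a functional assay on NCI-H226 cells (Homo sapiens) for inhibition, read by MTT assay, with a stated time of 48 h, tested at 10 uM; a lower number here means less inhibition, a higher number more inhibition at the concentration tested (going by the name of the read-out): in this assay compound 1 gives 41.3%. The other, compound 2 `COc1cc(NC(=O)Nc2cc(Nc3ccc(F)c(Cl)c3)ncn2)cc(OC)c1`, gives 36.7% in this assay, and the two values lie within the usual scatter of each other, so no order between them can be claimed. Compound 3 `COc1cc(Br)ccc1Nc1cc(NC(=O)Nc2c(Cl)cccc2Cl)ncn1` is not yet measured in this assay. It keeps the core of compound 1 and differs from it in one place: 4-bromo-2-methoxyphenyl in place of 3,4-dimethylphenyl on a nitrogen on an aromatic ring. Within the data shown here, no pair of measured compounds differing in a single place is available, so the size of such a step is unknown from the data. Without such a guide, the step of a number 1.3 percentage points lower from compound 1 to compound 3 (within the scatter) is expected to stay within the scatter. Compound 3 is therefore estimated to give 40% in this assay, with a range from 22% to 58%.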

Compound 3, a percentage reported as inhibition, at one concentration (the size of the read-out at that concentration, not a potency): 43%
For compound 3 the middle estimate is 3 percentage points below the measured one; the measured number falls inside the stated range.
By their numbers in this assay, from the lowest: compounds 2, 1 and 3 (each within the scatter of the next).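

In this assay, among these compounds, putting 4-bromo-2-methoxyphenyl in place of 3,4-dimethylphenyl on a nitrogen on an aromatic ring gives a number 1.7 percentage points higher from compound 1 to compound 3 (within the scatter), and this is the only single-place step available. The two groups differ in their atoms, with oxygen and bromine entering and 1 hydrogen-bond acceptor where the leaving group has none, yet the reading at this position stays within the scatter. Nothing measured here offers an explanation for this result.

Since the bromine and the methoxy group enter together, their separate contributions cannot be told apart. Also open, as far as these compounds go, is whether an amine, a carboxylic acid or a longer chain at this place, in place of these substituted phenyl groups, would move the reading beyond the scatter.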